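The compounds below may be only part of what the source reports. "The series", "measured", "known", "first", "only" and "open" are said of these compounds alone.

Compound 2 `CC1CCCCC1N(C(=O)c1cc(C2CC2)on1)C1CCCCC1` carries a cyclohexyl and a 2-methylcyclohexyl on the nitrogen of a shared core. In an assay on isolated protein for agonist activity at sphingosine 1-phosphate receptor 2 (Homo sapiens) (a lower number here means that less compound is needed, a higher number that more compound is needed for the effect), compound 2 gives only a limit, > 50000 nM. Compound 1 `CC1CCCCC1N(C(=O)c1cc(C2CC2)on1)C1CCCCC1C`, which bears a methyl on each of its two saturated rings, also gives only a limit in this assay, > 50000 nM. Compound 3 `O=C(c1cc(-c2ccccc2)on1)N(C1CCCCC1)C1CCCCC1`, which differs on the core and carries two unsubstituted cyclohexyl groups, likewise gives only a limit, > 50000 nM. For the measured compounds named here, the single step between measured compounds, a step that the two limits leave unreadable from compound 1 to compound 2, is therefore unreadable, since both of its ends sit at the limit of > 50000 nM in this assay, at which 3 of the 3 values shown sit. Compound 4 `O=C(c1cc(C2CC2)on1)N(C1CCCCC1)C1CCCCC1` is still to be measured; it differs from compound 2 by hydrogen in place of methyl on a saturated ring carbon. Going by the values given here, because a step that the two limits leave unreadable from compound 1 to compound 2 shows no readable size and every value so far rests on the limit, no readable change is expected in this assay from removing the methyl. Compound 4 is therefore estimated at 80000 nM, within 20000 nM to 400000 nM, an expected step that the limit leaves unreadable from compound 2 to compound 4, most likely reported again only as a limit.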

Compound 4, half-maximal effective concentration: > 50000 nM
Compound 4: no number, only a limit; the forecaster's own chance of this, stated with the estimate: 85%; the middle value does not contradict the limit.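

In this assay compound 4 gives only a limit, > 50000 nM and so its steps from compound 2 and from compound 3 cannot be read: the limit of > 50000 nM in this assay, at which 4 of the 4 values shown sit.
The compounds shown leave open whether hydrogen in place of methyl, or cyclopropyl in place of phenyl, changes the result in this assay at all.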